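Series notes: propyl to cyclohexyl step toward compound 3

A few compounds are considered here, and "the series" means these few. Any claim that something is new, unique, unknown or untested is made for them only; others in the source may bear on it.

Measured so far:
compound 1 `O=C(O)/C(=N/OC(c1ccc(OCc2ccc3ccccc3n2)cc1)C1CCCCC1)c1ccccc1`: 31 nM
compound 2 `CCCCC(O/N=C/C(=O)O)c1ccc(OCc2ccc3ccccc3n2)cc1`: 52 nM

In a functional assay for inhibition of Polyunsaturated fatty acid 5-lipoxygenase (Homo sapiens) (on this read-out lower numbers stand for stronger inhibition and higher numbers for weaker inhibition), compound 1 gives 31 nM and compound 2 gives 52 nM. Compound 2 holds the higher of the two numbers, but its gap to compound 1 lies within the usual scatter, so no order between them is claimed. Compound 3 `O=C(O)/C=N/OC(CC1CCCCC1)c1ccc(OCc2ccc3ccccc3n2)cc1` has not been measured. It differs from compound 2 by cyclohexyl in place of propyl on a saturated chain carbon, two bonds along the chain from an aromatic carbon and an oxygen on an unsaturated carbon. Within the data shown here, no step between measured compounds covers this change, so no shift beyond the scatter is expected in this assay in either direction. Compound 3 is estimated at 45 nM, within a range of 15 nM to 140 nM. The estimate implies a 1.2-fold lower number from compound 2 to compound 3 (0.06 log units; within the scatter), a step expected to stay within the scatter.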

Compound 3, half-maximal inhibitory concentration: 27 nM
Beside the measured number, compound 3's estimate is 1.7-fold (0.22 log units) above it; low and high end bracket the measured number.
By their numbers in this assay, from the lowest: compounds 3, 1 and 2 (each within the scatter of the next).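

In this assay, cyclohexyl in place of propyl on this saturated chain carbon gives a 1.9-fold lower number from compound 2 to compound 3 (0.28 log units; within the scatter) and so moves the read-out no further than the scatter. This position therefore accepts a six-membered non-aromatic ring of carbon only, with more heavy atoms than propyl, and the number stays in the same range. Nothing at hand gives a reason for this result.

As far as these compounds go, whether a phenyl ring, an amine or a longer chain at this place would also stay within the scatter remains open.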